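This account rests on a few compounds, and the source may have more. Where it says the series, first, only, none or still open, it means among the compounds named here.

Among the compounds with values here, in a physicochemical assay for solubility, in simulated intestinal fluid, with a stated time of 4 h (a higher number here means a more soluble compound, a lower number a less soluble compound), compound 1 `N#Cc1ccc(O[C@H]2CN(S(=O)(=O)c3ccc(Cl)cc3Cl)C[C@@]2(O)CO)cc1F` gives 19 ug/mL and stands highest of the two numbers measured so far, with compound 2 `N#Cc1ccc(O[C@H]2CN(S(=O)(=O)c3ccc(C(F)(F)F)cc3)C[C@@]2(O)CO)cc1F` at 5 ug/mL as its only neighbour. The unmeasured compound 3 `N#Cc1ccc(O[C@H]2CN(S(=O)(=O)c3ccc(Cl)cc3Cl)C[C@@]2(O)CN)cc1F` keeps the core of compound 1 and differs by amino in place of hydroxy on a saturated chain carbon bound to a saturated ring carbon in one place: amino in place of hydroxy on a saturated chain carbon bound to a saturated ring carbon, so hydroxymethyl becomes aminomethyl. Within the data shown here, the only measured step, a 3.8-fold lower number from compound 1 to compound 2 (0.58 log units; beyond the scatter) for 4-(trifluoromethyl)phenyl in place of 2,4-dichlorophenyl on a sulfonyl sulfur, lies elsewhere in the molecule, so it offers a sense of size but no direction. Among the measured compounds shown here, a similarly modest step in this assay is expected, probably upward, though no measurement yet supports that direction. The estimate means a 1.8-fold higher number from compound 1 to compound 3 (0.27 log units; within the scatter) as the expected step. Compound 3 is thus estimated at 35 ug/mL with a likely range of 10 ug/mL to 120 ug/mL around that figure.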

Compound 3, solubility: 78 ug/mL
Compound 3: the middle estimate sits 2.2-fold (0.35 log units) below what was measured; low and high end bracket the measured number.
By their numbers in this assay, from the lowest: compound 2; then compound 1; then compound 3.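

In this assay, within the data shown here, amino in place of hydroxy gives a 4.1-fold higher number from compound 1 to compound 3 (0.61 log units; beyond the scatter), the first measured change at this position on a saturated chain carbon bound to a saturated ring carbon. The earlier pair differed only on the sulfonyl sulfur, so it gave no direction here; this position now has a measured upward step beyond the scatter. The change is small in atoms, with one oxygen replaced by one nitrogen and the listed hydrogen-bond donor and acceptor counts unchanged, and no measurement shown explains the step.

From the compounds shown here alone, whether hydroxymethyl to aminomethyl gives a similar step with the 4-(trifluoromethyl)phenyl group of compound 2 remains open. So does the outcome with a methylamino group, a carboxylic acid or a longer aminoethyl chain at this position.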